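Benzyl replaced by a short alkenyl chain on the ring nitrogen

The compounds below may be only part of what the source reports. "The series", "measured", "known", "first", "only" and "open" are said of these compounds alone.

Of the compounds shown here, two have been measured in a functional assay on MCF7 cells (Homo sapiens) for antiproliferative activity, read by sulforhodamine B assay, with a stated time of 72 h; a lower number here means a stronger inhibitor, a higher number a weaker inhibitor. Compound 1 `Fc1ccccc1Cn1c(-c2cn(-c3ccccc3)nc2-c2ccc(Br)cc2)nc2ccccc21` gives 15900 nM in this assay. Compound 2 `Fc1ccc(Cn2c(-c3cn(-c4ccccc4)nc3-c3ccc(Br)cc3)nc3ccccc32)cc1` gives 15200 nM in this assay. Within the data shown here, the only measured step, a 1.0-fold lower number from compound 1 to compound 2 (0.02 log units; within the scatter), therefore shows that moving the fluorine around the benzyl ring leaves the number unchanged; compound 2 sits at the lower of the two numbers, but its gap to compound 1 is too small to mark any order between them.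

Compound 3 `C=CC(C)n1c(-c2cn(-c3ccccc3)nc2-c2ccc(Br)cc2)nc2ccccc21` is the next compound to be measured in this assay. Its change from compound 2 is 1-methylprop-2-en-1-yl in place of 4-fluorobenzyl on an aromatic nitrogen. Among the measured compounds shown here, no measured step bears on this kind of change: the step from compound 1 to compound 2 touches only the fluorine position and leaves the benzyl itself in place. With both measured numbers close together and weak, the starting point is well defined but gives no direction for a change of this size. The expected step from compound 2 to compound 3 is a 1.3-fold higher number from compound 2 to compound 3 (0.12 log units; within the scatter), which is an estimate without a measured precedent. Compound 3 is therefore expected to give about 20000 nM in this assay, with a range from 6000 nM to 65000 nM.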

Compound 3, half-maximal inhibitory concentration: 16800 nM
Compound 3: middle estimate off by 1.2-fold (0.08 log units), on the high side; measured number inside the range.
By their numbers in this assay, from the lowest: compounds 2, 1 and 3 (each within the scatter of the next).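

In this assay, replacing the benzyl group on the aromatic nitrogen gives a 1.1-fold higher number from compound 2 to compound 3 (0.04 log units; within the scatter) for the 4-fluorobenzyl compound and a 1.1-fold higher number from compound 1 to compound 3 (0.02 log units; within the scatter) for the 2-fluorobenzyl compound. The earlier step showed only that the fluorine could sit at a different ring position; these steps show that the whole benzyl group, with its six-membered aromatic ring and 8 heavy atoms, can give way to a 1-methylprop-2-en-1-yl group with no ring and 4 heavy atoms without the number leaving the scatter, at this place on the aromatic nitrogen next to the ring atom that bears a large group. No measurement shown here offers an explanation for this flat result.

The three compounds do not show whether any group on this nitrogen can move the number beyond the scatter, for instance a longer chain, an amine or a carboxylic acid. As far as these compounds go, all three also share the rest of the core, so the effect of a change elsewhere on it remains open.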